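Hydrazone aryl variation on the shared core

This account rests on a few compounds, and the source may have more. Where it says the series, first, only, none or still open, it means among the compounds named here.

Measured so far:
- compound 2 `CN(C)CCn1cnnc1-c1cc(Oc2ccc(NC(=O)N/N=C/c3ccc(O)c(Br)c3)cc2F)ccn1`: 1860 nM
- compound 1 `CN(C)CCn1cnnc1-c1cc(Oc2ccc(NC(=O)N/N=C/c3cc(C(C)(C)C)cc(C(C)(C)C)c3O)cc2F)ccn1`: 3300 nM

In a functional assay on MKN-45 cells (Homo sapiens) for cytotoxicity, read by MTT assay, with a stated time of 72 h (on this read-out lower numbers stand for stronger inhibition and higher numbers for weaker inhibition), compound 2 gives 1860 nM and compound 1 gives 3300 nM; the two numbers lie within the usual scatter of each other, so no ranking between them is read off. Compound 3 `CN(C)CCn1cnnc1-c1cc(Oc2ccc(NC(=O)N/N=C/c3ccc(F)cc3F)cc2F)ccn1` is not yet measured. It carries 2,4-difluorophenyl in place of 3-bromo-4-hydroxyphenyl on a carbon with a double bond to nitrogen. For the measured compounds named here, no step between measured compounds covers this change; the hydroxyl donor is lost, and a weakening beyond the scatter is expected. For compound 3 the estimate in this assay is 3800 nM, between 1300 nM and 11000 nM, a step of a 2.0-fold higher number from compound 2 to compound 3 (0.31 log units; beyond the scatter).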

Compound 3, half-maximal inhibitory concentration: 810 nM
Estimate against measurement, compound 3: 4.7-fold (0.67 log units) above, and the stated range ends above it.
By their numbers in this assay, from the lowest: compound 3; then compounds 2 and 1 (each within the scatter of the next).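

In this assay, 2,4-difluorophenyl in place of 3-bromo-4-hydroxyphenyl on the carbon with a double bond to nitrogen gives a 2.3-fold lower number from compound 2 to compound 3 (0.36 log units; beyond the scatter) and so a modest gain. A hydrogen-bond donor on this aryl group is thus not needed for a number at this level. No measurement on hand explains the shift.

The swap changes the hydroxyl, the bromine and the fluorines at once, so their separate contributions remain unresolved. As far as these compounds go, how an amine or a carboxylic acid on this aryl ring would read also remains open.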